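Cyclopentylsulfanyl in place of isobutylamino on the shared core

The source may report more compounds than this note shows. Statements on the series, on what has been measured and on what is new or still open speak of the compounds shown alone.

In an ADME assay on CCRF-HSB-2 cells (Homo sapiens) for cytotoxicity, with a stated time of 7 days (on this read-out lower numbers stand for higher toxicity in this test and higher numbers for lower toxicity in this test), the measured compounds read as follows:

compound 1 `CCCSc1nc(N)nc2c1ncn2/C=C1/CC1(CO)CO` gives 98000 nM as a number
compound 2 `Nc1nc(NCc2ccccc2)c2ncn(/C=C3/CC3(CO)CO)c2n1` gives > 20000 nM (a limit)
compound 3 `CC(C)CNc1nc(N)nc2c1ncn2/C=C1/CC1(CO)CO` gives > 20000 nM (a limit)

Compound 3 gives > 20000 nM as a limit of the assay and not as a number. It stands at the limit of > 20000 nM in this assay, at which 2 of the 3 values shown sit, and so has no exact place among the values. Compound 4 `Nc1nc(SC2CCCC2)c2ncn(/C=C3/CC3(CO)CO)c2n1` has not yet been measured, and it differs from compound 3 as follows: cyclopentylsulfanyl in place of isobutylamino on an aromatic carbon on an aromatic carbon.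

Among the measured compounds shown here, three measured steps bear on this change: a step that the limit leaves unreadable from compound 1 to compound 3, a step that the limit leaves unreadable from compound 1 to compound 2 and a step that the two limits leave unreadable from compound 2 to compound 3. None of them gives a size. For the measured compounds named here, compound 1 is the only measured compound with a sulfanyl group, and it gives 98000 nM with propylsulfanyl. Compound 4 is therefore expected to lie near it in this assay, though no firm direction can be expected from compound 3.

The expected change is a step that the limit leaves unreadable from compound 3 to compound 4 and remains an estimate. For compound 4 the estimated value is 60000 nM, with an expected range from 15000 nM to 200000 nM in this read-out.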

Compound 4, half-maximal cytotoxic concentration: 91000 nM
The estimate for compound 4 lay 1.5-fold (0.18 log units) below the measured number, within the range that was stated.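

In this assay, cyclopentyl in place of propyl on a sulfur gives a 1.1-fold lower number from compound 1 to compound 4 (0.03 log units; within the scatter). Among the compounds shown here, this is the first step at this position with a number at both ends, and it shows that an open propyl chain and a five-membered carbon ring on the sulfur read alike here. The steps to compound 4 from compound 2 and from compound 3 cannot be read, as those two compounds with an amino link give only a limit of the assay and not a number: the limit of > 20000 nM in this assay, at which 2 of the 4 values shown sit.

As far as these compounds go, how far the compounds with an amino link lie from those with a sulfanyl link remains open. Also open, from the compounds shown here alone, is how a cyclopentyloxy group, with oxygen in place of the sulfur, or a longer chain on the sulfur would read in this assay.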